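The source may hold more compounds than are shown below. What is called first, only, known or untested is meant among the compounds shown, and "the series" means these compounds.

The series shares one core. Compound 1 `COc1cc(-c2cc(/C=C/C(=O)c3ccc(N)cc3)[nH]n2)cc(OC)c1OC` gives 5390 nM in a functional assay on U-251 cells (Homo sapiens) for inhibition, read by sulforhodamine B assay, with a stated time of 48 h (on this read-out lower numbers stand for higher toxicity in this test and higher numbers for lower toxicity in this test), the second highest of the three numbers: compound 3 `COc1ccc(-c2cc(/C=C/C(=O)c3cc(OC)c(OC)c(OC)c3)[nH]n2)cc1OC` gives 5130 nM, and compound 2 `COc1ccc(-c2cc(/C=C/C(=O)c3ccc(N)cc3)[nH]n2)cc1OC` gives 7690 nM, both within the scatter of compound 1. Among the measured compounds shown here, the only single-point step seen so far, a 1.4-fold higher number from compound 1 to compound 2 (0.15 log units; within the scatter), concerns hydrogen in place of methoxy on an aromatic carbon and does not touch the carbonyl side. Compound 4 `COc1ccc(C(=O)/C=C/c2cc(-c3cc(OC)c(OC)c(OC)c3)n[nH]2)cc1OC` differs from compound 1 by 3,4-dimethoxyphenyl in place of 4-aminophenyl on a carbonyl carbon. For the measured compounds named here, no measured step bears on this exchange; the values of compound 1 and compound 3 merely show that methoxy-bearing and amino-bearing aryl ketones give similar numbers. The expected step in this assay is therefore a 1.0-fold higher number from compound 1 to compound 4 (0.01 log units; within the scatter), none beyond the scatter. Compound 4 is estimated at 5500 nM, between 2500 nM and 12000 nM.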

Compound 4, concentration lethal to 50% of the cells: 4990 nM
Beside the measured number, compound 4's estimate is 1.1-fold (0.04 log units) above it, and the stated range covers the measured number.
By their numbers in this assay, from the lowest: compounds 4, 3, 1 and 2 (each within the scatter of the next).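

In this assay, among the compounds shown here, the exchange of 4-aminophenyl for 3,4-dimethoxyphenyl on a carbonyl carbon gives a 1.1-fold lower number from compound 1 to compound 4 (0.03 log units; within the scatter) and is the first direct reading at this position. The entering group carries no hydrogen-bond donor and has more heavy atoms, yet the number stays within the scatter. No measurement here accounts for this result.

Going by these compounds, whether a carboxylic acid, a morpholine or a longer chain on this carbonyl carbon would shift the number remains open. So does whether any change at this position can move it beyond the scatter.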